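Amino Removal on Two Double-Bond Isomers

The compounds below may be only part of what the source reports. "The series", "measured", "known", "first", "only" and "open" are said of these compounds alone.

Compound 1 `COc1ccc(/C=C\c2ccc3c(c2)C(C)(C)CCC3(C)C)cc1N`: 25000 nM
Compound 2 `COc1ccc(/C=C\c2ccc3c(c2)C(C)(C)CCC3(C)C)cc1`: 50000 nM
Compound 3 `COc1ccc(/C=C/c2ccc3c(c2)C(C)(C)CCC3(C)C)cc1N`: 61000 nM

These three compounds were measured in a functional assay on HL-60 cells (Homo sapiens) for cytotoxicity; a lower number here means a stronger inhibitor, a higher number a weaker inhibitor. Compound 2 is made from compound 1 by hydrogen in place of amino on an aromatic carbon, a change that gave a 2.0-fold higher number from compound 1 to compound 2 (0.30 log units; within the scatter). Compound 3 and compound 1 share every atom and bond, and the difference between their cores is only (the two compounds have the same atoms and bonds and differ only in configuration as drawn: 1 of 1 stereo elements differ; a double bond is drawn Z in compound 1 and E in compound 3); this gave a 2.4-fold higher number from compound 1 to compound 3 (0.39 log units; beyond the scatter), which rests on (the fact that compounds 1 and 3 differ only in the configuration as drawn). Compound 4 `COc1ccc(/C=C/c2ccc3c(c2)C(C)(C)CCC3(C)C)cc1` has not yet been measured in this assay. It stands to compound 3 as compound 2 stands to compound 1: the change is hydrogen in place of amino on an aromatic carbon, at the same place on the ring in both pairs. The step from compound 3 to compound 4 is expected to be about a 1.8-fold higher number from compound 3 to compound 4 (0.26 log units; within the scatter), on the strength of a 2.0-fold higher number from compound 1 to compound 2 (0.30 log units; within the scatter). Compound 4 is therefore estimated at 110000 nM, between 50000 nM and 250000 nM.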

Compound 4, half-maximal inhibitory concentration: 50000 nM
Compound 4: the middle estimate sits 2.2-fold (0.34 log units) above what was measured; the measured number falls inside the stated range.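

In this assay, putting hydrogen in place of amino on the core of compound 3 gave a 1.2-fold lower number from compound 3 to compound 4 (0.09 log units; within the scatter), and this step does not differ from the earlier one on the core of compound 1: the same change on two cores in this assay, a 2.0-fold higher number (0.30 log units; within the scatter) from compound 1 to compound 2 and a 1.2-fold lower number (0.09 log units; within the scatter) from compound 3 to compound 4, 2.4-fold (0.39 log units) apart, within the scatter of two such steps. Among the two double-bond isomers without the amino group, the result was no change at the digits printed from compound 2 to compound 4 (within the scatter), a comparison that rests on one point: the fact that compounds 2 and 4 differ only in the configuration as drawn. Both amino steps lie within the scatter, so the change can be said to read alike on these two cores, but this does not show that the amino group matters on either core, or that the agreement would hold on any other.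

The compounds shown leave open whether a different group at the same place on the ring, such as a hydroxyl, a methyl or a carboxylic acid, would give a step beyond the scatter. They also leave open whether an amide formed on the amino group would separate the two double-bond isomers.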